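The source may report more compounds than this note shows. Statements on the series, on what has been measured and on what is new or still open speak of the compounds shown alone.

In a functional assay on PC-3 cells (Homo sapiens) for inhibition, read by colorimetric assay and MTT assay, with a stated time of 72 h (on this read-out lower numbers stand for stronger inhibition and higher numbers for weaker inhibition), compound 1 (`C=CCCCCOc1ccccc1-c1cnc(OCCCCC=C)n1C`) gives 9000 nM and compound 2 (`C=CCCCCOc1ncc(-c2ccccc2OC)n1C`) gives 24000 nM. Compound 3 (`Cn1c(-c2ccccc2O)cnc1S(=O)(=O)c1ccccc1`) reads > 100000 nM, which is a limit of the assay and not a number. Its place on the scale is the limit of > 100000 nM in this assay, at which 1 of the 3 values shown sits. Compound 4 (`C=CCCOc1ccccc1-c1cnc(S(=O)(=O)c2ccccc2)n1C`) carries but-3-en-1-yl in place of hydrogen on an oxygen on an aromatic ring, so the hydroxy becomes (but-3-en-1-yl)oxy. The nearest measured step is a 2.7-fold higher number from compound 1 to compound 2 (0.43 log units; beyond the scatter), which shortens a chain on such an oxygen rather than removing one. On that modest evidence, a lower number beyond the scatter is expected in this assay. The expected change is an at least 2.5-fold lower number from compound 3 to compound 4 (0.39 log units; beyond the scatter). For compound 4 the estimated value is 40000 nM, with an expected range of 12000 nM to 100000 nM.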

Compound 4, half-maximal inhibitory concentration: 42000 nM
For compound 4 the middle estimate is 1.1-fold (0.02 log units) below the measured one; the measured number falls inside the stated range.
By their numbers in this assay, from the lowest: compound 1; then compounds 2 and 4 (each within the scatter of the next). At a limit, above all of these: compound 3.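

Putting but-3-en-1-yl in place of hydrogen on the oxygen on the aromatic ring gives an at least 2.3-fold lower number from compound 3 to compound 4 (0.37 log units; beyond the scatter) in this assay. Where the earlier step only shortened a chain on such an oxygen, this one sets a free hydroxy against a chain and shows that the chain carries a measurable gain. Compound 3 stands at a limit of the assay and not at a number, so this size is only a minimum: the limit of > 100000 nM in this assay, at which 1 of the 4 values shown sits.

The compounds shown leave open whether a longer chain on this oxygen would go further. They also leave open how a chain ending in an amine or a carboxylic acid would read here.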